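Triazole aryl swap: fluorine for dimethyl substitution

The source may report more compounds than this note shows. Statements on the series, on what has been measured and on what is new or still open speak of the compounds shown alone.

Measured so far in a functional assay on PC-3 cells (Homo sapiens) for inhibition, read by MTT assay, with a stated time of 72 h; on this read-out lower numbers stand for stronger inhibition and higher numbers for weaker inhibition:
- compound 2 `Cc1ccc(-n2cc(CNC(=O)c3cccc4c3cnn4C(C)C)nn2)cc1C`: 23400 nM
- compound 3 `CC(C)n1ncc2c(C(=O)NCc3cn(-c4cccc(Br)c4)nn3)cccc21`: 33700 nM
- compound 1 `CC(C)n1ncc2c(C(=O)Nc3cccnc3)cccc21`: only a limit, > 40000 nM

Compound 2 holds the lowest of the two numbers in this assay. Its nearest neighbour is compound 3, reached by a 1.4-fold higher number from compound 2 to compound 3 (0.16 log units; within the scatter), which is within the scatter, so the two values cannot be ordered. Compound 1 sits at the limit of > 40000 nM in this assay, at which 1 of the 3 values shown sits, and contributes no number.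

The step to compound 4 `CC(C)n1ncc2c(C(=O)NCc3cn(-c4cccc(F)c4)nn3)cccc21` is 3-fluorophenyl in place of 3,4-dimethylphenyl on an aromatic nitrogen. Within the data shown here, the only measured step that bears on it is a 1.4-fold higher number from compound 2 to compound 3 (0.16 log units; within the scatter), where a different 3-substituted phenyl took the place of the 3,4-dimethylphenyl on the same aromatic nitrogen and the number moved within the scatter. On that basis no step beyond the scatter is expected for this assay from compound 2 to compound 4, in either direction.

Compound 4 is therefore estimated at 30000 nM, with a range from 14000 nM to 60000 nM. The expected step is a 1.3-fold higher number from compound 2 to compound 4 (0.11 log units; within the scatter), and a reading that comes back only as a limit remains possible given compound 1.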

Compound 4, half-maximal inhibitory concentration: 36100 nM
The estimate for compound 4 lay 1.2-fold (0.08 log units) below the measured number; the measured number falls inside the stated range.
By their numbers in this assay, from the lowest: compounds 2, 3 and 4 (each within the scatter of the next). At a limit, above all of these: compound 1.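

In this assay, 3-fluorophenyl on the aromatic nitrogen stays within the scatter of 3,4-dimethylphenyl, with a 1.5-fold higher number from compound 2 to compound 4 (0.19 log units; within the scatter). Among these compounds, the earlier compounds gave only one swap at this position, whereas a change of the halogen alone can now be read: fluoro in place of bromo on an aromatic carbon gives a 1.1-fold higher number from compound 3 to compound 4 (0.03 log units; within the scatter). The 3,4-dimethylphenyl, 3-bromophenyl and 3-fluorophenyl groups therefore cannot be ordered at this position, and nothing measured here gives a cause for these steps.

As far as these compounds go, it remains open whether a phenyl carrying an amine or a carboxylic acid, or a longer alkyl chain in place of the phenyl, would move the number beyond the scatter. From the compounds shown here alone, it also remains open whether these three groups would stay equivalent on another read-out.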